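The compounds below may be only part of what the source reports. "The series", "measured", "known", "first", "only" and "open" are said of these compounds alone.

Measured so far:
Compound 1, `Cc1cccc(CN2CC=C(CCC(=O)NO)C2=O)c1`, gives 2500 nM.
Compound 2, `CC(C)(C)c1ccc(CCCN2CC=C(CCC(=O)NO)C2=O)cc1`, gives 2520 nM.

Both numbers come from a functional assay on NCI-H23 cells (Homo sapiens) for inhibition, read by sulforhodamine B assay; a higher number here means a weaker inhibitor of growth, a lower number a stronger inhibitor of growth. Compound 1 and compound 2 share the same core and differ only in what hangs off the ring and in the length of the linker to the ring nitrogen, yet their numbers are practically the same: the gap between them is within the usual scatter of this assay, so neither can be called the stronger inhibitor. Compound 1 is simply one of two very similar numbers.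

The next compound, compound 3, `O=C(CCC1=CCN(Cc2cccc(Br)c2)C1=O)NO`, keeps everything of compound 1 except one substituent on the six-membered aromatic ring of carbon only: bromo in place of methyl on an aromatic carbon. Among the compounds with values here, a methyl and a bromo are both single heavy atoms without donors or acceptors, and the data so far give no example of such a swap changing this read-out. The step from compound 1 to compound 3 is therefore expected to be small, a 1.3-fold lower number from compound 1 to compound 3 (0.10 log units; within the scatter), with no clear direction beyond the scatter. Compound 3 is estimated to give 2000 nM, in the range 700 nM to 6000 nM.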

Compound 3, concentration for 50% growth inhibition: 2500 nM
Compound 3: the middle estimate sits 1.3-fold (0.10 log units) below what was measured, within the range that was stated.
By their numbers in this assay, from the lowest: compounds 1, 3 and 2 (each within the scatter of the next).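

In this assay, within the data shown here, the one change of bromo in place of methyl on an aromatic carbon, meta to a large group, gives no change at the digits printed from compound 1 to compound 3 (within the scatter) and so leaves this read-out where it was. Among these compounds, this is the first comparison that isolates a single place, as compound 1 and compound 2 differ both in what hangs off the ring and in the linker to the ring nitrogen, so it shows directly that this position accepts this particular exchange without a visible shift in growth inhibition. No separate measurement here speaks to why the two groups read alike.

The compounds shown leave open whether an amine, a carboxylic acid or a longer chain at this same place would move the number beyond the scatter, since methyl and bromo are each a single heavy atom with no hydrogen-bond donors or acceptors. They also leave open whether the linker length matters on its own, which compound 1 and compound 2 cannot settle with two changes made at once.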